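A few compounds are considered here, and "the series" means these few. Any claim that something is new, unique, unknown or untested is made for them only; others in the source may bear on it.

In an ADME assay on HS27 cells (Homo sapiens) for cytotoxicity, read by MTT assay (on this read-out higher numbers stand for weaker inhibition and lower numbers for stronger inhibition), compound 1 `COC(=O)c1ccc2c(ccn2-c2cccc(NC(=O)Nc3ccc(Cl)c(C(F)(F)F)c3)c2)n1` gives > 10000 nM, which is a limit of the assay and not a number. Compound 2 `O=C(Nc1ccc(-n2ccc3nc(C(=O)NCc4ccccc4)ccc32)cc1)c1ccc(Cl)c(C(F)(F)F)c1` gives 1500 nM in this assay. Compound 3 `O=C(Nc1ccc(-n2ccc3nc(C(=O)NCc4ccccc4)ccc32)cc1)Nc1cccc(Cl)c1Cl` gives > 10000 nM in this assay, again a limit of the assay. The one step that can be sized, an at least 6.6-fold higher number from compound 2 to compound 3 (0.82 log units; beyond the scatter), sets compound 3 at the weaker end of what is shown, at the limit of > 10000 nM in this assay, at which 2 of the 3 values shown sit. Compound 4 `O=C(Nc1ccc(-n2ccc3nc(C(=O)NCc4ccccc4)ccc32)cc1)c1cccc(C(F)(F)F)c1` differs from compound 3 by 3-(trifluoromethyl)phenyl in place of (2,3-dichlorophenyl)amino on a carbonyl carbon. This change turns the urea-type linkage of compound 3 back into the carbonyl-linked aryl amide that compound 2 carries, so the step of an at least 6.6-fold higher number from compound 2 to compound 3 (0.82 log units; beyond the scatter) is the nearest guide, read in reverse, though the aryl group of compound 4 lacks the chlorine of compound 2. The author therefore expects a step towards stronger inhibition in this assay, of about an at least 3.3-fold lower number from compound 3 to compound 4 (0.52 log units; beyond the scatter). Compound 4 is estimated at 3000 nM, with a range from 1000 nM to 10000 nM, while a further limit reading cannot be ruled out.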

Compound 4, half-maximal inhibitory concentration: > 10000 nM
Compound 4: only a limit was reported; the forecaster's own chance of this, stated with the estimate: 35%; at least 3.3-fold (0.52 log units) between middle value and limit.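

In this assay compound 4 gives > 10000 nM, which is a limit of the assay and not a number. Hydrogen in place of chloro on an aromatic carbon, with nothing else changed, gives an at least 6.6-fold higher number from compound 2 to compound 4 (0.82 log units; beyond the scatter), so the carbonyl-linked aryl amide alone does not keep the reading off the limit, and compound 2 remains the only compound shown with a number. The step between compound 3 and compound 4 cannot be read, as both are limits, and most of the series now rests at a single reading: the limit of > 10000 nM in this assay, at which 3 of the 4 values shown sit.

On these data alone, how far past the limit compound 1, compound 3 and compound 4 lie stays open, so no order among them can be given. Also open, as far as these compounds go, is whether bromo or methoxy on that aromatic carbon would give a measurable reading, as chloro does in compound 2.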